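The compounds below may be only part of what the source reports. "The series", "measured", "known", "first", "only" and "open" are said of these compounds alone.

Measured so far:
compound 1 `Cc1ccc(C(=O)Nc2cc3nc(C4CCCCC4)[nH]c3cc2N(C)C)cc1` — > 100 ug/mL
compound 2 `CCN(CC)c1cc2[nH]c(C3CCCCC3)nc2cc1NC(=O)c1ccc(N(C)C)cc1` — "not determined" (no result reported)
compound 3 `C=Cc1cccc(C(=O)Nc2cc3nc(C4CCCCC4)[nH]c3cc2N(CC)CC)c1` — > 100 ug/mL

In an ADME assay on Vero cells (Chlorocebus sabaeus) for cytotoxicity, read by resazurin assay, with a stated time of 3 days (on this read-out lower numbers stand for stronger inhibition and higher numbers for weaker inhibition), compound 3 stands only at a limit of the assay, > 100 ug/mL, and not at a number. Compound 1 likewise stands at a limit, > 100 ug/mL. Compound 2 has no result in this assay. Going by the values given here, what is shared by the two values given is the limit of > 100 ug/mL in this assay, at which 2 of the 3 values shown sit, so no step between measured compounds can be read from them.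

Compound 4 `CCN(CC)c1cc2[nH]c(C3CCCCC3)nc2cc1NC(=O)c1ccc(C)cc1` differs from compound 3 in one place: 4-methylphenyl in place of 3-vinylphenyl on a carbonyl carbon. Among the compounds with values here, with no measured step to lean on, and because compound 1 shows the same limit in this assay, > 100 ug/mL, a step of about none beyond the scatter is expected, with the assay most likely again reporting only a limit.

The estimate for compound 4 in this assay is 150 ug/mL, within 60 ug/mL to 400 ug/mL. The expected step is a step that the limit leaves unreadable from compound 3 to compound 4.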

Compound 4, half-maximal inhibitory concentration: > 100 ug/mL
Compound 4: no number, only a limit (the forecaster's own chance of this, stated with the estimate: 80%); the middle value is on the limit's open side.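

In this assay compound 4 gives > 100 ug/mL, a limit and not a number, so no step to compound 4 can be read from compound 3 or compound 1: the limit of > 100 ug/mL in this assay, at which 3 of the 4 values shown sit.

The compounds shown leave open where any actual value lies in this assay, and whether either change alters it.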